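The source may report more compounds than this note shows. Statements on the series, on what has been measured and on what is new or still open speak of the compounds shown alone.

Going by the values given here, compound 1 `Clc1ccc(-c2cc(-c3ccccc3)c3cc(Br)ccc3n2)cc1` is the only compound in this set with a measured number. In a functional assay on Hep2C cells (Homo sapiens) for antiproliferative activity, read by MTT assay, with a stated time of 24 h (a lower number here means a stronger inhibitor, a higher number a weaker inhibitor), compound 1 gives 269000 nM, which places it among weak inhibitors, and it serves as the sole point of reference here. Compound 2 `O=[N+]([O-])c1cccc(-c2cc(-c3ccccc3)c3cc(Br)ccc3n2)c1` shares the same core, but in this assay compound 2 gives "not determined" (no result reported), so it contributes no number to compare against.

Compound 3 `N#Cc1ccc(-c2cc(-c3ccccc3)c3cc(Br)ccc3n2)cc1` differs from compound 1 in a single place: cyano in place of chloro on an aromatic carbon. Among the compounds with values here, with only one measured value on hand, no step between measured compounds is available to calibrate how this assay responds to a swap of this kind. The replacement of chloro by cyano on the aromatic carbon leaves the core untouched, and the expectation is therefore a step in this assay no larger than the ordinary scatter, in no particular direction, so that the step from compound 1 to compound 3 is estimated at a 1.0-fold lower number from compound 1 to compound 3 (0.01 log units; within the scatter). Compound 3 is thus expected to give 260000 nM, with a plausible range from 110000 nM to 650000 nM.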

Compound 3, half-maximal inhibitory concentration: 98800 nM
Compound 3: middle estimate off by 2.6-fold (0.42 log units), on the high side; the whole stated range lies above it.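

The position para to a large group on the 4-chlorophenyl part of the shared core is not indifferent in this assay: cyano in place of chloro gives a 2.7-fold lower number from compound 1 to compound 3 (0.43 log units; beyond the scatter), a step that lies beyond the scatter. Going by these compounds alone, this is the first measured step in the set, and it shows that a change at this single position, with the rest of the molecule untouched, can move the number toward stronger inhibition, with compound 3 at 98800 nM. Nothing available here explains why the swap has this effect, so the result stands as an observation about these two compounds only.

A single step cannot show whether this gain is particular to cyano or would also appear with other groups at the same position, such as an amine, a methoxy group or a carboxylic acid, and compound 2, which has no reported result, adds nothing on this point. From the compounds shown here alone, it also remains open whether the phenyl group and the bromine on the shared core, unchanged in these compounds, would respond to substitution at all.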